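A few compounds are considered here, and "the series" means these few. Any claim that something is new, unique, unknown or untested is made for them only; others in the source may bear on it.

Measured in a functional assay on LS174T cells (Homo sapiens) for inhibition, with a stated time of 4 days, tested at 1 uM; a higher number here means a stronger effect of the compound at the concentration tested, a lower number a weaker effect:
compound 1 `Fc1cccc(F)c1C#Cc1cncc2ccccc12`: 16.5%
compound 2 `Nc1ncc(C#Cc2c(F)cccc2F)c2ccccc12`: 86.2%
compound 3 `Fc1cccc(F)c1C#Cc1ccc2ccccc2n1`: 67.3%

Compound 2 stands highest of the three, with compound 3 nearest and compound 1 furthest; both gaps lie beyond the scatter. Within the data shown here, the one single-point step among them is a number 69.7 percentage points higher from compound 1 to compound 2 (beyond the scatter), a large rise. Compound 4 `CNc1ncc(C#Cc2c(F)cccc2F)c2ccccc12` differs from compound 2 by methyl in place of hydrogen on a nitrogen on an aromatic ring. Among the measured compounds shown here, no measured step bears on this change directly: the amino-for-hydrogen step shows only that the nitrogen matters, not what a methyl on it does. With nothing to point either way, the expected step in this assay is a number 8.2 percentage points lower from compound 2 to compound 4 (within the scatter), within the scatter. Compound 4 is accordingly estimated at 78%, with a range of 55% to 95%.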

Compound 4, a percentage reported as inhibition, at one concentration (the size of the read-out at that concentration, not a potency): 99.8%
Estimate against measurement, compound 4: 21.8 percentage points below; measured number above the stated range.
By their numbers in this assay, from the lowest: compound 1; then compound 3; then compound 2; then compound 4.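

In this assay the amino nitrogen of compound 2 accepts a methyl, and the step is upward: a number 13.6 percentage points higher from compound 2 to compound 4 (beyond the scatter) with methyl in place of hydrogen on a nitrogen on an aromatic ring. A hydrogen on this nitrogen is therefore not needed to keep the read-out at this concentration, and methylamino in place of hydrogen on an aromatic carbon gives a number 83.3 percentage points higher from compound 1 to compound 4 (beyond the scatter) overall. Nothing available explains the gain from this methyl.

On these data alone, whether an ethyl, a longer chain or a second methyl on this nitrogen holds the number stays open. With compound 4 at 99.8% in this assay near the top of a percentage scale, any further gain would be hard to resolve at this concentration.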